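The source may hold more compounds than are shown below. What is called first, only, known or untested is meant among the compounds shown, and "the series" means these compounds.

Three compounds have been measured so far in a physicochemical assay for lipophilicity; a higher number here means a more lipophilic compound, a lower number a more polar compound:

Compound 1 `CCOC(=O)/C=C(C)/C=C/CC(C)CCCC(C)CC` gives 7.81 in this assay.
Compound 2 `CCOC(=O)/C=C(C)/C=C/CC(C)CCC(OC)C(C)C` gives 5.54 in this assay.
Compound 3 `C=C(C)CCCC(C)C/C=C/C(C)=C/C(=O)OCC` gives 6.19 in this assay.

Compound 3 holds the second highest of these three numbers. Its nearest neighbour is compound 2, and the step of a number 0.65 log units higher from compound 2 to compound 3 (beyond the scatter) separates them. The furthest is compound 1, and the step of a number 1.62 log units lower from compound 1 to compound 3 (beyond the scatter) is large. The remaining step, a number 2.27 log units lower from compound 1 to compound 2 (beyond the scatter), is the largest of all three.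

Compound 4 `C=C(C)CCCC(C)C/C=C/C(C)=C/C(=O)OC(C)C` is the next compound, and it differs from compound 3 by methyl in place of hydrogen on a saturated chain carbon bound to an oxygen next to a carbonyl group and a saturated chain carbon. None of the three measured steps touches this part of the molecule: all of them exchanged groups at the far end of the chain, and all were modest or large. Among the measured compounds shown here, there is therefore no measured step that bears directly on the change from compound 3 to compound 4, and the expectation can rest only on the smallness of the change itself. Compound 4 is expected to lie a little higher than compound 3 in this assay, with the step of a number 0.41 log units higher from compound 3 to compound 4 (beyond the scatter) expected to sit near the edge of the scatter. For compound 4 the estimate in this assay is 6.6, with a range from 6.2 to 7.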

Compound 4, partition coefficient: 6.6
Compound 4: the middle estimate sits on the measured number at the digits printed; the range from low to high includes it.
By their numbers in this assay, from the lowest: compound 2; then compound 3; then compound 4; then compound 1.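

Among the compounds shown here, the change of ethoxycarbonyl to isopropoxycarbonyl gives the first reading at this place in this assay, with a number 0.41 log units higher from compound 3 to compound 4 (beyond the scatter) for methyl in place of hydrogen on a saturated chain carbon bound to an oxygen next to a carbonyl group and a saturated chain carbon. The earlier steps shown here all exchanged groups at another place, so this result shows that the number also moves beyond the scatter when the change is made here, even though only one carbon enters and the rest of compound 3 stays the same. Nothing shown explains why the number moves by this amount at this place.

The compounds shown give a single step at this place, on a single background, so they leave open whether the same change would give a step of similar size on the chain of compound 1 or compound 2. They also leave open how this assay would read with a longer chain such as butoxycarbonyl, with a carboxylic acid, or with an amide in place of ethoxycarbonyl.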